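The source may report more compounds than this note shows. Statements on the series, on what has been measured and on what is new or still open speak of the compounds shown alone.

Working notes on the sulfone series. In a functional assay on DLD-1 cells (Homo sapiens) for antiproliferative activity, read by trypan blue exclusion (a lower number here means a stronger inhibitor, a higher number a weaker inhibitor), compound 2 `COc1ccc(CS(=O)(=O)/C=C/c2c(OC)cc(OC)cc2OC)cc1` gives 40 nM, while compound 1 `COc1ccc(CS(=O)(=O)/C=C/c2ccc(F)cc2OC)cc1` gives 15000 nM. Compound 3 `COc1ccc(CS(=O)(=O)/C=C/c2c(OC)cc(O)cc2OC)cc1` returns no number in this assay but only a limit, > 20000 nM. That places compound 3 at the limit of > 20000 nM in this assay, at which 1 of the 3 values shown sits, so its true position is open above that point. Within the data shown here, the single measured step that reaches it, an at least 500-fold higher number from compound 2 to compound 3 (2.69 log units; beyond the scatter), is a loss well beyond the scatter and is the only direct evidence on the hydroxy-bearing compound.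

Compound 4 `COc1ccc(CS(=O)(=O)/C=C/c2c(OC)cc(F)cc2OC)cc1` is the next variation: fluoro in place of hydroxy on an aromatic carbon. Among the measured compounds shown here, no measured pair covers an exchange of hydroxy for fluoro at this carbon, so the step from compound 3 to compound 4 has no precedent of its own; the step from compound 2 to compound 3 shows only how far the hydroxy compound fell, and the fluoro compound 1 differs from the others in more than one place. Because compound 3 sits at a limit, the expected step of an at least 13-fold lower number from compound 3 to compound 4 (1.12 log units; beyond the scatter) is itself uncertain and is taken as a partial recovery. Compound 4 is therefore estimated at 1500 nM, with a plausible range from 150 nM to 20000 nM.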

Compound 4, half-maximal inhibitory concentration: 750 nM
Beside the measured number, compound 4's estimate is 2.0-fold (0.30 log units) above it; the measured number falls inside the stated range.
By their numbers in this assay, from the lowest: compound 2; then compound 4; then compound 1. At a limit, above all of these: compound 3.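

In this assay, fluoro in place of hydroxy at this carbon, meta to two methoxy groups, gives an at least 26-fold lower number from compound 3 to compound 4 (1.42 log units; beyond the scatter), a step that is only a bound, compound 3 being a limit: the limit of > 20000 nM in this assay, at which 1 of the 4 values shown sits. Fluoro does not match methoxy at this carbon, with a 19-fold higher number from compound 2 to compound 4 (1.27 log units; beyond the scatter), so a small exchange here still moves the number well beyond the scatter, and the recovery from hydroxy is only partial. With fluoro held in place, methoxy in place of hydrogen on an aromatic carbon also counts, giving a 20-fold lower number from compound 1 to compound 4 (1.30 log units; beyond the scatter), which shows that the added methoxy group matters even without the methoxy at this carbon.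

From the compounds shown here alone, the true size of the step from hydroxy to fluoro stays open, as compound 3 has no number. Going by these compounds, whether an amine, a chlorine or a methyl group at this carbon would fall nearer compound 2 or compound 4 also stays open.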